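Swapping carboxy for (diisopropylamino)methyl

A few compounds are considered here, and "the series" means these few. Any claim that something is new, unique, unknown or untested is made for them only; others in the source may bear on it.

In a functional assay on SW480 cells (Homo sapiens) for antiproliferative activity, read by MTT assay, with a stated time of 48 h (a higher number here means a weaker inhibitor, a lower number a stronger inhibitor), compound 1 `COC/C1=C/C[C@](C)(CCC=C(C)C)/C=C/[C@@H](OC(=O)C=C(C)C)[C@](C)(OC)/C=C/C1=O` gives 14600 nM and compound 2 `COC/C1=C/C[C@](C)(CCC=C(C)C)/C=C/[C@@H](OC(=O)C=C(C)C)[C@](C)(O)/C=C/C1=O` gives 3850 nM as measured values. Between them lies a 3.8-fold lower number from compound 1 to compound 2 (0.58 log units; beyond the scatter) for the change on the oxygen.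

Compound 3 `CC(C)=CCC[C@]1(C)/C=C/[C@@H](OC(=O)C=C(C)C)[C@](C)(O)/C=C/C(=O)/C(C(=O)O)=C\C1` reads > 10000 nM in this assay and this is a limit of the assay, not a number.

Compound 4 `CC(C)=CCC[C@]1(C)/C=C/[C@@H](OC(=O)C=C(C)C)[C@](C)(O)/C=C/C(=O)/C(CN(C(C)C)C(C)C)=C\C1` differs from compound 3 by one change ((diisopropylamino)methyl in place of carboxy on a double-bonded ring carbon). For the measured compounds named here, the only measured step at this ring carbon is an at least 2.5-fold higher number from compound 2 to compound 3 (0.41 log units; beyond the scatter) and there carboxy came with the higher number. Compound 4 loses that carboxy and keeps the hydroxy group of compound 2, so the 3850 nM of compound 2 is the closest guide. Going by the values given here, no measured compound carries the incoming group, which leaves the expectation wide. The expected change is an at least 2.5-fold lower number from compound 3 to compound 4 (0.39 log units; beyond the scatter) and it points towards a stronger inhibitor. Compound 4 is estimated at 4000 nM with an expected range from 1200 nM to 12000 nM in this assay for now.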

Compound 4, half-maximal inhibitory concentration: 750 nM
Estimate against measurement, compound 4: 5.3-fold (0.73 log units) above; measured number outside the range, below it.
By their numbers in this assay, from the lowest: compound 4; then compound 2; then compound 1.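

For the compounds shown here, until now, the only step read at this double-bonded ring carbon in this assay went towards a weaker inhibitor; now the same carbon also gives a gain, with a 5.1-fold lower number from compound 2 to compound 4 (0.71 log units; beyond the scatter) for diisopropylamino in place of methoxy on the saturated chain carbon bound to it. The position can therefore do more than lose activity, and the swap away from carboxy gives an at least 13-fold lower number from compound 3 to compound 4 (1.12 log units; beyond the scatter). That step is only a floor, for compound 3 carries a limit of the assay and not a number: the limit of > 10000 nM in this assay, at which 1 of the 4 values shown sits.

Going by these compounds, whether a smaller amine such as dimethylamino, or a ring amine such as piperidine, would match diisopropylamino at this position remains open. Equally open, on these data alone, is whether the gain would hold with methoxy in place of the hydroxy group of compound 4.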